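Three Phenyl Substituents, One Cell Assay, One Open Question

This account rests on a few compounds, and the source may have more. Where it says the series, first, only, none or still open, it means among the compounds named here.

This account concerns a small set of compounds sharing one core. Compound 1 `CCSc1ccc(-c2cncnc2-c2cc(OC)c(OC)c(OC)c2)cc1` was tested in a functional assay on SiHa cells (Homo sapiens) for antiproliferative activity, read by CCK-8 assay, with a stated time of 72 h (a lower number here means a stronger inhibitor, a higher number a weaker inhibitor), and gives 1030 nM. Compound 2 `CCOc1ccc(-c2cncnc2-c2cc(OC)c(OC)c(OC)c2)cc1Cl` gives 150 nM in this assay, and compound 3 `CCOc1ccc(-c2cncnc2-c2cc(OC)c(OC)c(OC)c2)cc1C(F)(F)F` gives 20000 nM. Compound 1 therefore stands second highest of the three numbers, its nearest neighbour being compound 2 and its furthest compound 3.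

Among the measured compounds shown here, the one measured single-point step, a 130-fold higher number from compound 2 to compound 3 (2.12 log units; beyond the scatter), shows that the outer ring of this core tolerates substituent changes poorly: a large step in the weaker direction follows from exchanging one small group for another. The change from compound 1 to compound 4 `COc1cc(-c2ncncc2-c2ccc(B(O)O)cc2)cc(OC)c1OC` is a group of 3 heavy atoms (1 boron, 2 oxygen; no ring) in place of a group of 3 heavy atoms (2 carbon, 1 sulfur; no ring), on an aromatic carbon. For the measured compounds named here, no measured step swaps a group on that position for one of boron and oxygen, so the expectation for compound 4 leans only on the sensitivity seen between compound 2 and compound 3, and points toward a weaker number.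

Compound 4 is expected to give about 3500 nM in this assay, with a range from 700 nM to 18000 nM, which means an estimated step of a 3.4-fold higher number from compound 1 to compound 4 (0.53 log units; beyond the scatter).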

Compound 4, half-maximal inhibitory concentration: 17500 nM
Estimate against measurement, compound 4: 5.0-fold (0.70 log units) below; low and high end bracket the measured number.
By their numbers in this assay, from the lowest: compound 2; then compound 1; then compounds 4 and 3 (each within the scatter of the next).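

Among the compounds shown here, with a 17-fold higher number from compound 1 to compound 4 (1.23 log units; beyond the scatter) in this assay, a change on an aromatic carbon para to a large group now has a measured step of its own, whereas the one earlier step concerned chloro and trifluoromethyl. This exchange of ethylsulfanyl for the group of boron and oxygen leaves the count of heavy atoms unchanged and still gives a large step toward the weaker side, so that count alone does not settle the result at this position. Nothing available here accounts for the size of this step.

The compounds shown leave open how an amine, a carboxylic acid or a longer chain would read at this position. They also do not tell whether the boron or the two hydrogen-bond donors of the entering group go with the weaker number.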